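Swapping the aryl group on the sulfonyl of compound 1

A few compounds are considered here, and "the series" means these few. Any claim that something is new, unique, unknown or untested is made for them only; others in the source may bear on it.

Measured so far in a functional assay on K562 cells (Homo sapiens) for inhibition, read by trypan blue exclusion, with a stated time of 72 h; a higher number here means a weaker inhibitor, a lower number a stronger inhibitor:
Compound 1 `COc1ccc(S(=O)(=O)c2cc3cnc(Nc4ccc5[nH]ccc5c4)nc3n(C)c2=O)cc1` gives 300 nM.
Compound 2 `Cn1c(=O)c(S(=O)(=O)c2ccc(OC(=O)CCCCC3SCC4NC(=O)NC43)cc2)cc2cnc(Nc3ccc4[nH]ccc4c3)nc21` gives 600 nM.
Compound 3 `COc1ccc(S(=O)(=O)c2cc3cnc(Nc4cccc5[nH]ccc45)nc3n(C)c2=O)cc1` gives 5000 nM.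

Compound 1 has the lowest number of the three; compound 2 stands within the scatter of it, while compound 3 lies far from it, with a 17-fold higher number from compound 1 to compound 3 (1.22 log units; beyond the scatter). Compound 4 `Cn1c(=O)c(S(=O)(=O)c2ccc(F)cc2N)cc2cnc(Nc3ccc4[nH]ccc4c3)nc21` differs from compound 1 in one place: 2-amino-4-fluorophenyl in place of 4-methoxyphenyl on a sulfonyl sulfur. Within the data shown here, no measured step changes this group alone; the step from compound 1 to compound 3 concerns 1H-indol-4-yl in place of 1H-indol-5-yl and says nothing about it. Compounds 1 and 2, whose values differ only within the scatter, carry different groups on the sulfonyl sulfur, which hints that change there is tolerated. For compound 4 a step of about the scatter or less is therefore expected, in either direction, a 1.3-fold higher number from compound 1 to compound 4 (0.12 log units; within the scatter). Compound 4 is expected at 400 nM, within 100 nM to 1500 nM.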

Compound 4, half-maximal inhibitory concentration: 2000 nM
Beside the measured number, compound 4's estimate is 5.0-fold (0.70 log units) below it, and the stated range ends below it.
By their numbers in this assay, from the lowest: compounds 1 and 2 (each within the scatter of the next); then compound 4; then compound 3.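

Among these compounds, the step of a 6.7-fold higher number from compound 1 to compound 4 (0.82 log units; beyond the scatter) is the first measured change on the sulfonyl sulfur alone, and it lies beyond the scatter. The closeness of the values of compound 1 and compound 2 therefore does not mean that any aryl group is tolerated there. No measurement shown gives a reason for this loss.

Three things change at once in this swap: the methoxy group leaves, and an amino group and a fluorine enter. Which of them matters stays open, as does how 4-fluorophenyl, 2-aminophenyl or unsubstituted phenyl would compare on the same sulfur.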